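The compounds below may be only part of what the source reports. "The series", "measured", "known", "first", "only" and "open" are said of these compounds alone.

Measured so far in an ADME assay on A549 cells (Homo sapiens) for cytotoxicity, read by CellTiter-Glo; on this read-out lower numbers stand for higher toxicity in this test and higher numbers for lower toxicity in this test:
- compound 1 `Cc1c(Cc2ccc(OC(F)(F)F)cc2)c(=O)oc2cc(OCC(O)CN3CCC(C(N)=O)CC3)ccc12`, 68200 nM
- compound 2 `Cc1c(Cc2ccc(OC(F)(F)F)cc2)c(=O)oc2cc(OC[C@H](O)CN3CCC(C(N)=O)CC3)ccc12`, 52000 nM
- compound 3 `Cc1c(Cc2ccc(OC(F)(F)F)cc2)c(=O)oc2cc(OC[C@@H](O)CN3CCC(C(N)=O)CC3)ccc12`, 64900 nM

Compound 3 gives the second highest of the three numbers, and all three lie within the scatter of one another: the step of a 1.1-fold lower number from compound 1 to compound 3 (0.02 log units; within the scatter) and the step of a 1.2-fold higher number from compound 2 to compound 3 (0.10 log units; within the scatter) are both small, and so is the step of a 1.3-fold lower number from compound 1 to compound 2 (0.12 log units; within the scatter). Each of these steps concerns only the drawn configuration at a saturated chain carbon, as shown by the fact that one of compounds 1 and 2 is drawn with a defined configuration and the other without, at the place where they differ, the fact that one of compounds 1 and 3 is drawn with a defined configuration and the other without, at the place where they differ and (the fact that compounds 2 and 3 differ only in the configuration as drawn).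

Compound 4 `Cc1c(Cc2ccc(OC(F)(F)F)cc2)c(=O)oc2cc(OCC(O)CNc3nccs3)ccc12` departs from compound 3 in a different way: 1-hydroxy-2-((1,3-thiazol-2-yl)amino)ethyl in place of 2-(4-carbamoylpiperidin-1-yl)-1-hydroxyethyl on a saturated chain carbon bound to an oxygen on an aromatic ring. Among the measured compounds shown here, none of the measured steps touches this kind of exchange, since all of them compare the same atoms and bonds in different configurations. The three compounds only show that the shared core with the carbamoylpiperidinyl side chain sits at a weakly cytotoxic level in this assay, and nothing measured here tells how the thiazolylamino replacement shifts it.

For the measured compounds named here, with no step bearing on the change, compound 4 is expected to stay near the level of the measured compounds, with a wide margin: the estimate is 50000 nM, between 15000 nM and 150000 nM. This corresponds to an expected step of a 1.3-fold lower number from compound 3 to compound 4 (0.11 log units; within the scatter).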

Compound 4, half-maximal cytotoxic concentration: 99000 nM
Estimate against measurement, compound 4: 2.0-fold (0.30 log units) below, and the stated range covers the measured number.
By their numbers in this assay, from the lowest: compounds 2, 3, 1 and 4 (each within the scatter of the next).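

Among the compounds shown here, the earlier compounds varied only the drawn configuration, whereas compound 4 shows for the first time what an exchange of the side chain itself does at this place, on a saturated chain carbon bound to an oxygen on an aromatic ring. In this assay, replacing the 2-(4-carbamoylpiperidin-1-yl)-1-hydroxyethyl group, with its six-membered non-aromatic ring, by 1-hydroxy-2-((1,3-thiazol-2-yl)amino)ethyl, with its five-membered aromatic ring, stays within the scatter against each earlier compound (a 1.5-fold higher number from compound 3 to compound 4 (0.18 log units; within the scatter)) and (a 1.9-fold higher number from compound 2 to compound 4 (0.28 log units; within the scatter)) and (a 1.5-fold higher number from compound 1 to compound 4 (0.16 log units; within the scatter)), so this read-out tolerates a clear change of ring type and size at this place without a step beyond the scatter. What the compounds offer on configuration does not bear on this exchange, and nothing given accounts for the result.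

Since the ring and its link to the chain change together, the compounds leave open what the thiazole ring and the amino link each contribute on their own. Also open, going by these compounds, is whether a morpholine ring, a carboxylic acid or a longer chain at this place would stay at the same level, and whether the two configurations of compound 4 would match each other as those of compound 2 and compound 3 do.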